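Swapping Cyclopropyl for 3,5-Difluorophenyl on a Carbonyl Carbon

The source may hold more compounds than are shown below. What is called first, only, known or untested is meant among the compounds shown, and "the series" means these compounds.

Within the data shown here, only two compounds have been measured so far in a functional assay on A2780 cells (Homo sapiens) for antiproliferative activity, read by fluorescence, with a stated time of 72 h; on this read-out lower numbers stand for stronger inhibition and higher numbers for weaker inhibition. Compound 1 `CN1CCC(C(=O)N2Cc3c(NC(=O)C4CC4)n[nH]c3C2(C)C)CC1` gives 1420 nM, the higher of the two numbers. Compound 2 `CC(C)(C)C(=O)N1Cc2c(NC(=O)c3ccc(F)cc3)n[nH]c2C1(C)C` gives 270 nM, a lower number by more than the usual scatter. Compound 3 `CN1CCC(C(=O)N2Cc3c(NC(=O)c4cc(F)cc(F)c4)n[nH]c3C2(C)C)CC1` keeps the rest of compound 1 but carries 3,5-difluorophenyl in place of cyclopropyl on a carbonyl carbon. Among the measured compounds shown here, no pair of measured compounds isolates this change, so any forecast is uncertain. For the measured compounds named here, compound 2, at 270 nM, shows only that a number well under that of compound 1 can be reached in this small set. A move toward stronger inhibition, beyond the scatter, is therefore expected, with an estimated step of a 4.1-fold lower number from compound 1 to compound 3 (0.61 log units; beyond the scatter). For compound 3 the expected value is 350 nM, with an estimated range from 100 nM to 1200 nM.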

Compound 3, half-maximal inhibitory concentration: 130 nM
The estimate for compound 3 lay 2.7-fold (0.43 log units) above the measured number; the range from low to high includes it.
By their numbers in this assay, from the lowest: compound 3; then compound 2; then compound 1.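

In this assay the exchange of cyclopropyl for 3,5-difluorophenyl on the carbonyl carbon gives an 11-fold lower number from compound 1 to compound 3 (1.04 log units; beyond the scatter) and counts as a large step. Among these compounds, this is the first direct reading of this position: with the rest of compound 1 unchanged, the group on this carbonyl carbon alone moves the number well beyond the scatter. Nothing available accounts for the size of the step, so it stands as an observation only.

A single pair cannot separate the contribution of the aromatic ring from that of its two fluorine atoms, nor show whether their placement matters. An unsubstituted phenyl, a 4-fluorophenyl or a longer alkyl chain on the same carbonyl carbon, with the rest of compound 1 kept, remains an open comparison.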